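A Pyrimidine in Place of Pyridine on a Shared Core

The source may report more compounds than this note shows. Statements on the series, on what has been measured and on what is new or still open speak of the compounds shown alone.

Compound 1 `c1cncc(-c2ccccc2OCC2=NCCN2)c1`: in a functional assay for activation of Alpha-1A adrenergic receptor (Homo sapiens), read by calcium flux (on this read-out higher numbers stand for an effect only at larger amounts of compound and lower numbers for an effect already at smaller amounts), compound 1 gives 2 nM.
Compound 2 `c1ccc(-c2ccncc2)c(OCC2=NCCN2)c1`: in this assay compound 2 gives < 100000 nM, which is a limit of the assay and not a number.
Compound 3 `Cc1cccc(-c2ccccc2OCC2=NCCN2)n1`: in this assay compound 3 gives 126 nM.

Compound 2 therefore stands apart from the other two, since only a limit is known for it, as recorded in the limit of < 100000 nM in this assay, at which 1 of the 3 values shown sits. Among the measured compounds shown here, the one measured step that touches compound 2 is a step that the limit leaves unreadable from compound 1 to compound 2, and that limit leaves its size unreadable.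

Compound 4 `c1cnc(-c2ccccc2OCC2=NCCN2)nc1` differs from compound 2 by pyrimidin-2-yl in place of pyridin-4-yl on an aromatic carbon. For the measured compounds named here, no measured step bears on a pyrimidin-2-yl at this position, so the expectation rests on what the measured compounds show about rings attached here: compound 1 gives 2 nM, whereas compound 3 gives 126 nM. For compound 2 only a limit is known.

With that spread in mind, compound 4 is estimated at 300 nM, within a range from 30 nM to 5000 nM. The step from compound 2 to compound 4 is accordingly expected as a step that the limit leaves unreadable from compound 2 to compound 4, though, because compound 2 gives < 100000 nM only as a limit, its direction cannot be read with confidence.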

Compound 4, half-maximal effective concentration: 1260 nM
For compound 4 the middle estimate is 4.2-fold (0.62 log units) below the measured one, and the stated range covers the measured number.
By their numbers in this assay, from the lowest: compound 1; then compound 3; then compound 4.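

Pyrimidin-2-yl in place of pyridin-3-yl gives a 630-fold higher number from compound 1 to compound 4 (2.80 log units; beyond the scatter) in this assay, the first step at this position whose size can be read, and it shows how much the number here can depend on the attached ring. Compound 4 nevertheless gives 1260 nM, so a six-membered aromatic ring with 2 hetero atoms at this place still yields a measured number in this assay. Compound 2 is known only by a limit of the assay, so neither its step from compound 1 nor its step to compound 4 can be read: the limit of < 100000 nM in this assay, at which 1 of the 4 values shown sits.

The compounds shown leave open how a plain phenyl ring would read at this place, and so how much of the step belongs to each ring nitrogen on its own. They also leave open whether an amine or a methoxy group on the pyrimidin-2-yl would bring the number back towards that of compound 1, or whether the ring itself sets the number whatever it carries.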